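Cytotoxicity Limits Across Three Ether Side Chains and a Fourth

The source may hold more compounds than are shown below. What is called first, only, known or untested is meant among the compounds shown, and "the series" means these compounds.

The three measured compounds share one core and differ only in the group carried on a saturated chain carbon bound to an oxygen on an unsaturated carbon. In an ADME assay on HEL cells (Homo sapiens) for cytotoxicity, with a stated time of 3 days (on this read-out higher numbers stand for lower toxicity in this test and lower numbers for higher toxicity in this test), compound 1 `CCC1(Cc2ccccc2)OS(=O)(=O)C=C1OCC(=O)OC` gives > 400000 nM, which is a limit of the assay and not a number. Compound 2 `CCC1(Cc2ccccc2)OS(=O)(=O)C=C1OCc1ccc(F)cc1` gives >= 50000 nM in this assay, again a limit. Compound 3 `CCC1(Cc2ccccc2)OS(=O)(=O)C=C1OCCCc1ccccc1` stands at >= 20000 nM in this assay, also a limit; all three values shown are limits, so compound 3 cannot be placed above or below the others. The steps a step that the two limits leave unreadable from compound 1 to compound 2, a step that the two limits leave unreadable from compound 1 to compound 3 and a step that the two limits leave unreadable from compound 2 to compound 3 are therefore unreadable in size. Compound 4 `CCC1(Cc2ccccc2)OS(=O)(=O)C=C1OCc1ccc(C)cc1` differs from compound 3 by 4-methylphenyl in place of phenethyl on a saturated chain carbon bound to an oxygen on an unsaturated carbon. With every bearing step unreadable, no direction beyond the scatter can be expected for a step that the limit leaves unreadable from compound 3 to compound 4, and a further limit is the most probable outcome. Compound 4 is estimated at 50000 nM in this assay, in the range 20000 nM to 400000 nM.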

Compound 4, minimum cytotoxic concentration: >= 16000 nM
Compound 4: no number, only a limit; the forecaster's own chance of this, stated with the estimate: 80%; the middle value is on the limit's open side.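

In this assay, among these compounds, compound 4 gives >= 16000 nM as a limit of the assay and not a number, so no step between compound 4 and compound 1, compound 2 or compound 3 can be read. The compounds shown leave open whether these four side chains differ at all on this read-out.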